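The source may hold more compounds than are shown below. What is called first, only, known or untested is meant among the compounds shown, and "the series" means these compounds.

In a functional assay on the whole organism (heart left ventricle) with Canis familiaris (Canis lupus familiaris) as the target (a higher number here means that more compound is needed for the effect, a lower number that less compound is needed), compound 1 `COc1cc(OS(C)(=O)=O)ccc1-c1nc2cc[nH]cc-2n1` gives 0.002 mg/kg, compound 2 `COc1cc([S+](C)[O-])ccc1-c1cn2cccnc2n1` gives 2.4 mg/kg and compound 3 `COc1cc([S+](C)[O-])ccc1-c1cn2ccncc2n1` gives 0.75 mg/kg. Compound 3 therefore stands in the middle of the three. Its number is lower than that of compound 2 and higher than that of compound 1, and both gaps lie beyond the usual scatter.

The next molecule, compound 4 `COc1cc(C(N)=O)ccc1-c1cn2ccncc2n1`, keeps the core of compound 3 and changes one substituent: a group of 3 heavy atoms (1 carbon, 1 nitrogen, 1 oxygen; no ring) in place of a group of 3 heavy atoms (1 carbon, 1 oxygen, 1 sulfur; no ring), on an aromatic carbon. Carbamoyl enters on an aromatic carbon of a six-membered aromatic ring of carbon only, meta to a methoxy group.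

Within the data shown here, no measured pair here shows this swap, so the numbers offer no direct guide to its size. Compound 2 at 2.4 mg/kg and compound 3 at 0.75 mg/kg carry the same group on different cores, yet their values lie apart, so a wide range is the cautious choice. The estimated step is a 1.3-fold higher number from compound 3 to compound 4 (0.12 log units; within the scatter), which is expected to stay within the scatter, leaning slightly toward a higher number. For compound 4 the expected value in this assay is 1 mg/kg, with an estimated range from 0.2 mg/kg to 5 mg/kg.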

Compound 4, dose for half-maximal effect: 0.02 mg/kg
Compound 4: middle estimate off by 50-fold (1.70 log units), on the high side; the whole stated range lies above it.
By their numbers in this assay, from the lowest: compound 1; then compound 4; then compound 3; then compound 2.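

On the core shared by compound 3 and compound 4, the group on the six-membered aromatic ring of carbon only, meta to the methoxy group, has a strong influence in this assay: placing carbamoyl there instead of the sulfur-containing group gives a 38-fold lower number from compound 3 to compound 4 (1.57 log units; beyond the scatter), so much less compound is needed for the effect. Among these compounds, this is the first pair that differs in one place only, and it shows directly that the dose depends on the group at this position. The two groups have the same count of heavy atoms, so that count alone does not set the dose, and while carbamoyl adds a hydrogen-bond donor, nothing available connects that difference or any other feature to the size of the step.

On these data alone, it remains open whether this low dose is particular to carbamoyl or would also appear with a carboxylic acid, a nitrile or a methylamide at the same position. It is also unknown whether carbamoyl would produce a similar step on the different core of compound 2, which carries the same sulfur-containing group.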